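Aryl additions to the core of compound 1: notes

A few compounds are considered here, and "the series" means these few. Any claim that something is new, unique, unknown or untested is made for them only; others in the source may bear on it.

Measured in a functional assay on Jurkat cells (Homo sapiens) for cytotoxicity, with a stated time of 48 h; a lower number here means a stronger inhibitor, a higher number a weaker inhibitor:
- compound 1 `CCOC(=O)CC1C(C(=O)OCC)=C(N)Oc2ccccc21`: 91400 nM
- compound 2 `CCOC(=O)CC1C(C(=O)OCC)=C(N)Oc2cccc(-c3ccccc3)c21`: 44300 nM
- compound 3 `CCOC(=O)CC1C(C(=O)OCC)=C(N)Oc2c(-c3ccccc3)cccc21`: 49800 nM

The number for compound 1 is the highest of the three. Two measured steps start from it, and each puts phenyl in place of hydrogen on an aromatic carbon. The first is a 2.1-fold lower number from compound 1 to compound 2 (0.31 log units; beyond the scatter), a modest step. The second is a 1.8-fold lower number from compound 1 to compound 3 (0.26 log units; within the scatter). Both run in the same direction, but only the first clears the scatter.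

The next compound is compound 4 `CCOC(=O)CC1C(C(=O)OCC)=C(N)Oc2ccc(-c3cc(O)cc(OC)c3)cc21`, still to be measured. It keeps the shared core and differs from compound 1 by 3-hydroxy-5-methoxyphenyl in place of hydrogen on an aromatic carbon. In words, 3-hydroxy-5-methoxyphenyl replaces hydrogen on an aromatic carbon that is meta to a fused ring and para to a fused ring. Within the data shown here, the two phenyl steps are the closest guide, though neither involves a substituted phenyl, and no measured compound carries one. A modest move to a lower number is therefore expected, perhaps slightly larger than those two steps. The expected change in this assay is a 3.7-fold lower number from compound 1 to compound 4 (0.56 log units; beyond the scatter). For compound 4 the estimated value is 25000 nM, with an expected range from 7000 nM to 60000 nM.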

Compound 4, half-maximal inhibitory concentration: 4200 nM
For compound 4 the middle estimate is 6.0-fold (0.77 log units) above the measured one, outside the stated range (below it).
By their numbers in this assay, from the lowest: compound 4; then compounds 2, 3 and 1 (each within the scatter of the next, the first and the last beyond it).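

In this assay, 3-hydroxy-5-methoxyphenyl on the aromatic carbon that is meta to a fused ring and para to a fused ring gives a 22-fold lower number from compound 1 to compound 4 (1.34 log units; beyond the scatter), well past the two phenyl steps at other places on the shared core, a 2.1-fold lower number from compound 1 to compound 2 (0.31 log units; beyond the scatter) and a 1.8-fold lower number from compound 1 to compound 3 (0.26 log units; within the scatter). An aryl addition to this core is therefore not confined to modest changes, and this is the only step of large size among the compounds shown. No measurement shown here accounts for the size of this step.

Place and substitution change together in compound 4, so it remains open how much of the step belongs to this carbon and how much to the hydroxy and methoxy groups on the added ring; plain phenyl on this same carbon would separate the two. Also open, on these data alone, is whether the hydroxy group can give way to another group, such as an amine or a carboxylic acid, on the added ring while the number in this cytotoxicity read-out stays near that of compound 4.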